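Pyrazin-2-yl in place of pyrimidin-2-yl: working notes

A few compounds are considered here, and "the series" means these few. Any claim that something is new, unique, unknown or untested is made for them only; others in the source may bear on it.

Values so far in an ADME assay on KB cells (Homo sapiens) for cytotoxicity, read by MTT assay, with a stated time of 72 h (on this read-out lower numbers stand for higher toxicity in this test and higher numbers for lower toxicity in this test), are these:
- compound 1 `Clc1ccc(Nc2nc(-c3ccccn3)c(Cl)s2)nc1` gives 326000 nM
- compound 2 `Clc1ccc(Nc2nc(-c3ncccn3)c(Cl)s2)nc1` gives 66100 nM

Compound 2 holds the lower of the two numbers. Compound 3 `Clc1ccc(Nc2nc(-c3cnccn3)c(Cl)s2)nc1` carries pyrazin-2-yl in place of pyrimidin-2-yl on an aromatic carbon and is otherwise unchanged. Among the compounds with values here, the only measured step bearing on it is a 4.9-fold lower number from compound 1 to compound 2 (0.69 log units; beyond the scatter) at the same place, and it gives a guide to size only. In this assay a smaller step is expected, leaning towards a higher number. The expected step is a 1.5-fold higher number from compound 2 to compound 3 (0.18 log units; within the scatter) and remains an estimate. For compound 3 the estimated value is 100000 nM with an expected range of 35000 nM to 280000 nM until measured.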

Compound 3, half-maximal cytotoxic concentration: 3170 nM
The estimate for compound 3 lay 32-fold (1.50 log units) above the measured number; the whole stated range lies above it.
By their numbers in this assay, from the lowest: compound 3; then compound 2; then compound 1.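

In this assay pyrazin-2-yl and pyrimidin-2-yl have the same atoms and counts, yet the change gives a 21-fold lower number from compound 2 to compound 3 (1.32 log units; beyond the scatter) at this place, so this position separates two ring isomers sharply. Across the three groups, the span is a 100-fold lower number from compound 1 to compound 3 (2.01 log units; beyond the scatter) and exceeds the earlier single step. No evidence on the cause of these steps is at hand.

Going by these compounds, whether an amine or a carboxylic acid on the pyrazin-2-yl ring would keep compound 3's number remains open. So does the effect of pyridazin-3-yl at this place.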